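This account rests on a few compounds, and the source may have more. Where it says the series, first, only, none or still open, it means among the compounds named here.

Measured compounds:
- In a functional assay on HeLa cells (Homo sapiens) for cytotoxicity, read by MTT assay, with a stated time of 72 h, tested at 10 uM (on this read-out lower numbers stand for less inhibition of growth and higher numbers for more inhibition of growth at the one concentration tested), compound 1 `Cc1ccnc(/C(N)=N/NC(=S)N2CCOCC2)c1` gives 49.1%.
- In this assay compound 2 `Cc1ccnc(/C(N)=N/NC(=S)N2CCSCC2)c1` gives 39.2%.
- In this assay compound 3 `N/C(=N\NC(=S)N1CCCCC1)c1ccccn1` gives 55.7%.

Compound 3 has the highest of the three numbers, but its gap to compound 1 lies within the scatter, so the two cannot be told apart; only its gap to compound 2 is beyond the scatter. Compound 4 `Cc1ccnc(/C(N)=N/NC(=S)N2CCCCC2)c1` has not yet been measured. It differs from compound 3 by methyl in place of hydrogen on an aromatic carbon, placed on an aromatic carbon of a six-membered aromatic ring with 1 nitrogen, meta to a large group and opposite the ring nitrogen. Among the compounds with values here, the only measured step, a number 9.9 percentage points lower from compound 1 to compound 2 (within the scatter), changes the ring on the thiocarbonyl carbon and not the aromatic ring, so no measured step bears directly on adding this methyl. With no guidance either way, the expectation for compound 4 is a step of a number 3.7 percentage points lower from compound 3 to compound 4 (within the scatter) in this assay, that is, none beyond the scatter. Compound 4 is therefore estimated at 52%, with a range from 36% to 68%.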

Compound 4, percent growth inhibition at one concentration: 62.1%
The estimate for compound 4 lay 10.1 percentage points below the measured number, within the range that was stated.
By their numbers in this assay, from the lowest: compounds 2, 1, 3 and 4 (each within the scatter of the next, the first and the last beyond it).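

In this assay, placing methyl on the aromatic carbon opposite the ring nitrogen gives a number 6.4 percentage points higher from compound 3 to compound 4 (within the scatter), so this position accepts the methyl without a change that can be told from the scatter. With the methyl present on all three compounds, the ring on the thiocarbonyl carbon can now be compared directly: piperidin-1-yl gives a number 22.9 percentage points higher from compound 2 to compound 4 (beyond the scatter) against thiomorpholin-4-yl and a number 13 percentage points higher from compound 1 to compound 4 (beyond the scatter) against morpholin-4-yl, which places piperidin-1-yl clearly above both in these compounds. Nothing available explains why this ring change shifts growth inhibition.

The compounds shown leave open whether a methoxy group or a chlorine atom on the same aromatic carbon would move the number beyond the scatter. They also leave open whether a ring carrying an amine, such as piperazin-1-yl, on the thiocarbonyl carbon would match piperidin-1-yl.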